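Weak pyrimidine amides: benzyl to methylated cyclohexyl tail

The source may hold more compounds than are shown below. What is called first, only, known or untested is meant among the compounds shown, and "the series" means these compounds.

Of the compounds shown here, three have been measured in an assay on HeLa cells for displacement of a labelled ligand from adenosine receptor A3 (Homo sapiens), read by fluorescence polarization, with a stated time of 30 min; a lower number here means a stronger inhibitor, a higher number a weaker inhibitor. Compound 1 `COc1ccc(-c2cc(NC(=O)CCC(=O)NCC(=O)NC3CCCCC3)nc(-c3ccc(OC)cc3)n2)cc1` gives 35100 nM; compound 2 `COc1ccc(-c2cc(NC(=O)CCC(=O)NCC(=O)NCc3ccccc3)nc(-c3ccc(OC)cc3)n2)cc1` gives 26900 nM; compound 3 `COc1ccc(-c2cc(NC(=O)COCC(=O)NCC(=O)NCc3ccccc3)nc(-c3ccc(OC)cc3)n2)cc1` gives 64600 nM. Compound 3 carries the highest of the three numbers: compound 1 lies nearest, within the scatter, while compound 2 lies furthest, beyond it. Within the data shown here, the only single-point step so far, a 1.3-fold lower number from compound 1 to compound 2 (0.12 log units; within the scatter), stays within the scatter.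

Compound 4 `COc1ccc(-c2cc(NC(=O)COCC(=O)N(C)CC(=O)NC3CCCCC3)nc(-c3ccc(OC)cc3)n2)cc1` has not yet been measured. It differs from compound 3 by ((cyclohexylcarbamoyl)methyl)(methyl)amino in place of ((benzylcarbamoyl)methyl)amino on a carbonyl carbon. Among the measured compounds shown here, the measured step bearing on this is the benzyl-for-cyclohexyl exchange on an amide-type nitrogen, which moved the number within the scatter only; the added methyl on the amide nitrogen is covered by no measured pair, so nothing is known of its effect. The expected step of a 1.1-fold higher number from compound 3 to compound 4 (0.03 log units; within the scatter) is therefore none beyond the scatter. For compound 4 in this assay the estimate is 70000 nM, with a range from 25000 nM to 200000 nM.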

Compound 4, inhibition constant: 10100 nM
For compound 4 the middle estimate is 6.9-fold (0.84 log units) above the measured one, outside the stated range (below it).
By their numbers in this assay, from the lowest: compound 4; then compounds 2, 1 and 3 (each within the scatter of the next, the first and the last beyond it).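

Among these compounds, this position, the substituent on the carbonyl carbon, can move the number: a 6.4-fold lower number from compound 3 to compound 4 (0.81 log units; beyond the scatter), the first step to go beyond the scatter and the first change to leave compound 4 below the rest. The benzyl-for-cyclohexyl exchange alone, a 1.3-fold lower number from compound 1 to compound 2 (0.12 log units; within the scatter), stayed within the scatter, but that pair carries a different linker and no methyl on the amide nitrogen, and the present change also takes the group from 2 hydrogen-bond donors to 1. No evidence is available on the origin of this step.

Compound 4 carries the cyclohexyl ring and the methyl together, so the share of each in the step remains unresolved. Also open, on these data alone, is whether an ethyl on that amide nitrogen, or a cyclopentyl ring in place of cyclohexyl, would hold or extend the step.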